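Chloro for Ethyl on the Anilide of Compound 3

The source may hold more compounds than are shown below. What is called first, only, known or untested is meant among the compounds shown, and "the series" means these compounds.

Compound 1, `CSc1cccc(NC(=O)CN2CCC(c3cccc[n+]3[O-])CC2)c1`, gives 56% in a functional assay on HEK293 cells for agonist activity at D(4) dopamine receptor (Homo sapiens), read by FLIPR; on this read-out higher numbers stand for larger maximal responses and lower numbers for smaller maximal responses.
Compound 2, `Oc1ccc(N2CCN(Cc3nc4ccccc4[nH]3)CC2)nc1`, gives 70% in this assay.
Compound 3, `CCc1cccc(C)c1NC(=O)CN1CCC(c2ccccn2)CC1`, gives 70% in this assay.

Among the three measured compounds, compound 3 is level with compound 2 at the digits shown, a difference that lies within the scatter of repeated measurements, so no order between the two can be read from these numbers. Compound 1 stands apart from both: its value in this assay is lower than that of compound 3, a gap beyond the scatter.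

Compound 4, `Cc1cccc(Cl)c1NC(=O)CN1CCC(c2ccccn2)CC1`, has not yet been measured. It differs from compound 3 in one place: chloro in place of ethyl on an aromatic carbon. The methyl group on the other side of the anilide ring is kept, as is the whole of the shared core, so the change is confined to a single substituent on the aromatic carbon that sits ortho to the large group.

Going by the values given here, no pair of measured compounds carries this same change, so the size of the step from compound 3 to compound 4 in this assay cannot be read from the data; with only one substituent exchanged and the rest of the molecule unchanged, a step no larger than the scatter is expected, in either direction or none at all. Compound 4 is therefore estimated to reach 66% in this assay, with a range from 48% to 84%. That estimate corresponds to an expected step of a number 4 percentage points lower from compound 3 to compound 4 (within the scatter), within the usual scatter.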

Compound 4, largest response reached (reported as efficacy), in percent of the reference or control that the assay uses: 70%
Compound 4: middle estimate off by 4 percentage points, on the low side, within the range that was stated.
By their numbers in this assay, from the lowest: compound 1; then compounds 2, 3 and 4 (each within the scatter of the next).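

Chloro in place of ethyl on this aromatic carbon, ortho to a large group, is the first change in a single place that can be read in this assay, and it gives no change at the digits printed from compound 3 to compound 4 (within the scatter). The exchange removes ethyl, with 2 heavy atoms, and brings in chloro, with 1 heavy atom, while the read-out stays within the scatter, so at this position in this series the maximal response does not depend on which of these two groups is present. Nothing else is available to explain why the two groups read alike.

On these data alone, this is a single step on a single core, so it remains open whether an amine, a carboxylic acid or a longer chain such as propyl on the same aromatic carbon would also stay within the scatter of compound 3. As far as these compounds go, it also remains open whether chloro and ethyl would still read alike if the methyl group were replaced, or if the same exchange were carried into a compound with another core.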